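Swapping chloro for fluoro on a pyrazoline amine oxidase inhibitor

The compounds below may be only part of what the source reports. "The series", "measured", "known", "first", "only" and "open" are said of these compounds alone.

Measured compounds:
compound 1 `CCC(=O)N1N=C(c2ccccc2)CC1c1ccc(F)cc1`, 1150 nM
compound 2 `CCC(=O)N1N=C(c2ccc(OC)cc2)CC1c1ccccc1`, 25100 nM
compound 3 `CCC(=O)N1N=C(c2ccc(OC)cc2)CC1c1ccc(Cl)cc1`, 851 nM

In an assay on isolated protein for inhibition of Amine oxidase [flavin-containing] B (Bos taurus) (a higher number here means a weaker inhibitor, a lower number a stronger inhibitor), compound 3 gives the lowest of the three numbers; compound 1 lies within the scatter of it, while compound 2 sits far higher. Compound 4 `CCC(=O)N1N=C(c2ccc(OC)cc2)CC1c1ccc(F)cc1` differs from compound 3 by fluoro in place of chloro on an aromatic carbon, that is, 4-chlorophenyl becomes 4-fluorophenyl. Among the measured compounds shown here, the only step that bears on this position is a 29-fold lower number from compound 2 to compound 3 (1.47 log units; beyond the scatter), showing that a halogen at this place matters greatly. For the measured compounds named here, no step compares fluoro directly with chloro, so the size of the change is uncertain; fluoro is expected to fall between hydrogen and chloro. Compound 4 is therefore estimated at 3000 nM (range 900 nM to 12000 nM), a step of a 3.5-fold higher number from compound 3 to compound 4 (0.55 log units; beyond the scatter) expected toward weaker inhibition.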

Compound 4, half-maximal inhibitory concentration: 100000 nM
Compound 4: the middle estimate sits 33-fold (1.52 log units) below what was measured, and the stated range ends below it.
By their numbers in this assay, from the lowest: compounds 3 and 1 (each within the scatter of the next); then compound 2; then compound 4.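

In this assay the kind of halogen decides the outcome, since fluoro in place of chloro gives a 120-fold higher number from compound 3 to compound 4 (2.07 log units; beyond the scatter) and so loses the gain that chloro brought. Fluoro in place of hydrogen gives a 4.0-fold higher number from compound 2 to compound 4 (0.60 log units; beyond the scatter), so at this position fluoro brings no gain over hydrogen when methoxy is present. Methoxy in place of hydrogen gives an 87-fold higher number from compound 1 to compound 4 (1.94 log units; beyond the scatter), so with 4-fluorophenyl in the molecule, methoxy carries a large penalty. From the compounds shown here alone, whether a bromo group at this position would behave like chloro or like fluoro stays open, as does how chloro behaves without methoxy. Nothing measured here accounts for these differences.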